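Pentan-3-yl to neopentyl on the shared core

This account rests on a few compounds, and the source may have more. Where it says the series, first, only, none or still open, it means among the compounds named here.

Among the measured compounds shown here, in an in vitro ADME assay on microsomes from liver (Canis lupus familiaris) for metabolic stability (on this read-out higher numbers stand for fast clearance and lower numbers for slow clearance), compound 2 (`CCC(CC)[C@@H]1C(=O)N[C@H](C2Cc3ccccc3C2)C(=O)N1[C@@H](C(=O)N(C)C)c1ccc(C)nc1`) gives 1 mL.min-1.g-1 and holds the lower of the two numbers so far, while compound 1 (`Cc1ccc([C@H](C(=O)N(C)C)N2C(=O)[C@@H](C3Cc4ccccc4C3)NC(=O)[C@H]2CC(C)C)cn1`) gives 3000 mL.min-1.g-1 on the same read-out. Compound 3 (`Cc1ccc([C@H](C(=O)N(C)C)N2C(=O)[C@@H](C3Cc4ccccc4C3)NC(=O)[C@H]2CC(C)(C)C)cn1`) carries neopentyl in place of pentan-3-yl on a saturated ring carbon, and the change counts as neopentyl in place of pentan-3-yl on a saturated ring carbon in full. The two have the same atoms, joined differently.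

For the measured compounds named here, one measured step bears on this ring carbon: a 3000-fold lower number from compound 1 to compound 2 (3.48 log units; beyond the scatter) for pentan-3-yl in place of isobutyl, which is large and beyond the scatter. Going by the values given here, no measured compound carries neopentyl, so that step shows only that this carbon can move the number strongly. With compound 2 at 1 mL.min-1.g-1 as the low end of the span, a move upward is expected, probably beyond the scatter but well short of the full measured step. The expected step is a 20-fold higher number from compound 2 to compound 3 (1.30 log units; beyond the scatter) as a rough estimate with wide uncertainty. For compound 3 the estimated value is 20 mL.min-1.g-1 in this read-out, with an expected range from 1 mL.min-1.g-1 to 400 mL.min-1.g-1 for repeated measurements.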

Compound 3, intrinsic clearance in microsomes: 1 mL.min-1.g-1
Beside the measured number, compound 3's estimate is 20-fold (1.30 log units) above it; measured number inside the range.
By their numbers in this assay, from the lowest: compounds 2 and 3 (each within the scatter of the next); then compound 1.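

In this assay, the two ways of joining these five carbons on the saturated ring carbon cannot be told apart: exchanging pentan-3-yl for neopentyl gives no change at the digits printed from compound 2 to compound 3 (within the scatter). Among the compounds shown here, the low number is therefore not unique to pentan-3-yl, and a single methyl in place of hydrogen, on the saturated chain carbon bound to three saturated chain carbons in isobutyl, is enough for a 3000-fold lower number from compound 1 to compound 3 (3.48 log units; beyond the scatter), with compound 1 the only high compound of the three. Nothing at hand explains either the large step from isobutyl or the absence of a step between the two five-carbon groups.

Still open, as far as these compounds go, is how the number behaves on this ring carbon with a cyclohexyl group, a shorter chain such as ethyl, or a chain ending in a hydroxyl group or an amine. Also open, from the compounds shown here alone, is whether the large step from isobutyl recurs when the 2,3-dihydro-1H-inden-2-yl group or the dimethylamide of the shared core is replaced by another group.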